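The compounds below may be only part of what the source reports. "The series", "measured", "known", "first", "only" and "open" are said of these compounds alone.

Compound 2 (`C1=C(c2cccs2)CCC(N2CCN(c3ccccn3)CC2)C1`) stands in a functional assay on the whole organism with Rattus norvegicus as the target (a higher number here means that more compound is needed for the effect, a lower number that less compound is needed), only at a limit: compound 2 gives > 30 mg/kg as a limit and not a number. Compound 1 (`C1=C(c2ccccc2)CCC(N2CCN(c3ccccn3)CC2)C1`) gives > 30 mg/kg in this assay and this too is a limit. The evidence so far is thus the limit of > 30 mg/kg in this assay, at which 2 of the 2 values shown sit, and no actual number is available for either compound. Compound 3 (`C1=C(c2ccccn2)CCC(N2CCN(c3ccccn3)CC2)C1`) follows from compound 2 by pyridin-2-yl in place of thiophen-2-yl on a double-bonded ring carbon and so has pyridin-2-yl in place of thiophen-2-yl on a double-bonded ring carbon. For the measured compounds named here, the only measured step that bears on this change is a step that the two limits leave unreadable from compound 1 to compound 2 and it offers no size to carry forward. It concerns the same ring carbon, yet neither a size nor a direction can be taken from it, so no definite step is expected in this assay. The expected step that the limit leaves unreadable from compound 2 to compound 3 is therefore only a rough estimate and should not be read as a real trend. Compound 3 is expected at about 35 mg/kg with an estimated range from 12 mg/kg to 100 mg/kg and may well yield only a limit.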

Compound 3, dose for half-maximal effect: 5.8 mg/kg
Beside the measured number, compound 3's estimate is 6.0-fold (0.78 log units) above it, outside the stated range (below it).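

In this assay compound 3 shows that this double-bonded ring carbon can carry a group that yields an actual number, and the change from thiophen-2-yl to pyridin-2-yl brings an at least 5.1-fold lower number from compound 2 to compound 3 (0.71 log units; beyond the scatter). The comparison with phenyl shows an at least 5.1-fold lower number from compound 1 to compound 3 (0.71 log units; beyond the scatter) and here the two compounds differ only by a ring nitrogen in place of a ring carbon, so a six-membered aromatic ring alone does not go with the lower number. The step between compound 1 and compound 2 cannot be read, and phenyl and thiophen-2-yl therefore cannot be ordered, as both values are limits and not numbers: the limit of > 30 mg/kg in this assay, at which 2 of the 3 values shown sit.

On these data alone, how large the gain over either earlier group really is stays open, since only its lower bound can be read from the limits. The compounds shown also leave open whether the ring nitrogen must sit as it does in pyridin-2-yl, or whether pyridin-3-yl, pyridin-4-yl or pyrimidin-2-yl on the same ring carbon would keep a number like that of compound 3 in this assay.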